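Methyl on the furan: compound 1 to compound 4

The source may report more compounds than this note shows. Statements on the series, on what has been measured and on what is new or still open speak of the compounds shown alone.

Values in a functional assay on HeLa cells (Homo sapiens) for cytotoxicity, in the presence of a further agent that is not named here (on this read-out higher numbers stand for weaker inhibition and lower numbers for stronger inhibition), follow
compound 1 `Clc1ccc(-c2cc(-c3ccsc3)nc(-c3ccco3)c2)o1` gives > 50000 nM
compound 2 `Clc1ccc(-c2cc(-c3cccnc3)nc(-c3cccs3)c2)o1` gives 14600 nM
compound 3 `Clc1ccc(-c2cc(-c3ccoc3)cc(-c3cccs3)n2)cc1` gives 5530 nM

Compound 1 gives > 50000 nM in this assay, and this is a limit of the assay, not a number. It is the only reading of this kind in the series (the limit of > 50000 nM in this assay, at which 1 of the 3 values shown sits). Its true position is therefore open on one side, and any step starting from compound 1 inherits that uncertainty.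

Compound 4 `Cc1ccc(-c2cc(-c3ccc(Cl)o3)cc(-c3ccsc3)n2)o1` is still unmeasured. It differs from compound 1 by a single change, furan-2-yl to 5-methylfuran-2-yl: methyl in place of hydrogen on an aromatic carbon. Among the measured compounds shown here, no measured pair isolates this change, so its size cannot be read directly from the data. The expectation rests on the values alone. Compound 2 at 14600 nM and compound 3 at 5530 nM show that relatives of compound 1 can give numbers within the range of the assay. A modest move toward stronger inhibition is expected, though a second reading at the limit remains quite possible. The expected size is an at least 1.6-fold lower number from compound 1 to compound 4 (0.22 log units; that floor lies within the scatter). For compound 4 the estimated value is 30000 nM, with an expected range from 9000 nM to 70000 nM.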

Compound 4, half-maximal inhibitory concentration: > 50000 nM
Compound 4 ended at the assay's limit; the forecaster's own chance of this, stated with the estimate: 45%; at least 1.6-fold (0.22 log units) between middle value and limit.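

In this assay compound 4 gives > 50000 nM and this is a limit, not a number. Among the compounds shown here, with compound 1 also at a limit, no step from compound 1 to compound 4 can be read: the limit of > 50000 nM in this assay, at which 2 of the 4 values shown sit. The compounds shown leave open how far, if at all, the value in this assay moves with methyl in place of hydrogen on an aromatic carbon.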